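Trimming the amide side chain of a pyridine alkyne modulator

The compounds below may be only part of what the source reports. "The series", "measured", "known", "first", "only" and "open" are said of these compounds alone.

Of the compounds shown here, two have been measured in a functional assay on HEK293 cells for positive allosteric modulation of metabotropic glutamate receptor 5 (Rattus norvegicus), read by fluorescence and calcium flux; a higher number here means a larger maximal response, a lower number a smaller maximal response. Compound 1, `C[C@@H](NC(=O)c1ccc(C#Cc2ccc(F)cn2)cn1)C(C)(C)O`, gives 64.6%. Compound 2, `C[C@@H](NC(=O)c1ccc(C#Cc2cccc(F)c2)cn1)C(C)(C)C`, gives 66% in this assay. The two numbers sit within the scatter of each other, so neither compound can be said to reach a larger response than the other; compound 2 simply carries the larger of the two figures.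

Compound 3, `CC(C)[C@H](C)NC(=O)c1ccc(C#Cc2cccc(F)c2)cn1`, differs from compound 2 in one place: 1,2-dimethylpropyl in place of 1,2,2-trimethylpropyl on an amide-type nitrogen. The group on the amide-type nitrogen loses one carbon while the rest of the molecule is kept. For the measured compounds named here, no pair of measured compounds shows what such a change does here, so the expectation rests only on compound 2 itself. A step of a number 3 percentage points lower from compound 2 to compound 3 (within the scatter) is expected, which is to say no movement beyond the scatter in either direction. Compound 3 is therefore estimated at 63%, with a range from 45% to 80%.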

Compound 3, largest response reached (reported as efficacy), in percent of the reference or control that the assay uses: 66.7%
The estimate for compound 3 lay 3.7 percentage points below the measured number; measured number inside the range.
By their numbers in this assay, from the lowest: compounds 1, 2 and 3 (each within the scatter of the next).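

In this assay the swap of 1,2,2-trimethylpropyl for 1,2-dimethylpropyl on the amide-type nitrogen gives a number 0.7 percentage points higher from compound 2 to compound 3 (within the scatter) and so cannot be told apart from no effect. For the compounds shown here, this is the first pair here that differs in one place, and it shows that one carbon can leave this side chain without a measurable effect on the maximal response. Nothing at hand explains this result.

As far as these compounds go, it remains open whether a still shorter chain such as ethyl, or a ring such as cyclopropyl, on the same nitrogen would also give a response like that of compound 3. A single pair also cannot show whether the same swap would behave this way on a different core.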